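The source may hold more compounds than are shown below. What is called first, only, known or untested is meant among the compounds shown, and "the series" means these compounds.

In a functional assay on Huh-7 cells (Homo sapiens) for antiproliferative activity, read by sulforhodamine B assay, with a stated time of 72 h (a lower number here means a stronger inhibitor, a higher number a weaker inhibitor), compound 1 `FC(F)(F)c1ccc(CN2CCN(Cc3cc(-c4ccc(OCc5ccccc5)cc4)on3)CC2)cc1` gives 1700 nM. Compound 2 `Cc1ccccc1COc1ccc(-c2cc(CN3CCN(Cc4ccc(C(F)(F)F)cc4)CC3)no2)cc1` carries methyl in place of hydrogen on an aromatic carbon; the data show a 1.4-fold lower number from compound 1 to compound 2 (0.15 log units; within the scatter), and in this assay compound 2 gives 1200 nM. Compound 3 `N#Cc1cccc(COc2ccc(-c3cc(CN4CCN(Cc5ccc(C(F)(F)F)cc5)CC4)no3)cc2)c1` carries cyano in place of hydrogen on an aromatic carbon instead; the data show a 17-fold lower number from compound 1 to compound 3 (1.23 log units; beyond the scatter) and a 12-fold lower number from compound 2 to compound 3 (1.08 log units; beyond the scatter), and in this assay compound 3 gives 100 nM.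

Compound 4 `Cc1cc(OCc2cccc(C#N)c2)ccc1-c1cc(CN2CCN(Cc3ccc(C(F)(F)F)cc3)CC2)no1` differs from compound 3 by methyl in place of hydrogen on an aromatic carbon. This is the same kind of change as from compound 1 to compound 2, but on a different core, and at a place that is also meta to a (3-cyanobenzyl)oxy group rather than only ortho to a large group. Because a 1.4-fold lower number from compound 1 to compound 2 (0.15 log units; within the scatter) lay within the scatter, a step of a 1.1-fold higher number from compound 3 to compound 4 (0.04 log units; within the scatter) is expected. Compound 4 is therefore expected to give about 110 nM, likely between 40 nM and 300 nM.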

Compound 4, half-maximal inhibitory concentration: 1500 nM
Compound 4: the middle estimate sits 14-fold (1.13 log units) below what was measured; measured number outside the range, above it.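

In this assay, adding a methyl to an aromatic carbon of compound 3 weakens it sharply, with a 15-fold higher number from compound 3 to compound 4 (1.18 log units; beyond the scatter). Among the compounds shown here, the same kind of change therefore cannot be carried from one core to another as a fixed shift: the same change on two cores in this assay, a 1.4-fold lower number (0.15 log units; within the scatter) from compound 1 to compound 2 and a 15-fold higher number (1.18 log units; beyond the scatter) from compound 3 to compound 4, 21-fold (1.33 log units) apart, beyond the scatter of two such steps This is only one pair of steps, and the methyl differs in both core and place between them, so the data do not show which of the two matters or why the steps differ.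

Going by these compounds, it remains open whether a group other than methyl, such as fluorine, chlorine or methoxy, at the same place on compound 3 would also give a much higher number. On these data alone, whether a methyl at other places on compound 3 would do the same is also open.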